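Methyl for trifluoromethyl on the aryl ring of compound 3

The source may hold more compounds than are shown below. What is called first, only, known or untested is meant among the compounds shown, and "the series" means these compounds.

Of the compounds shown here, three sharing one core have been measured in an ADME assay on WEHI13 cells (Mus musculus) for cytotoxicity, read by MTT assay, with a stated time of 72 h; a lower number here means that less compound is tolerated, a higher number that more compound is tolerated. Compound 1 `CCN(CC)Cc1cc(-c2ccccc2)n(Nc2ccnc3cc(Cl)ccc23)c1C` gives 4380 nM, compound 2 `Cc1c(CN2CCCC2)cc(-c2ccc(F)cc2)n1Nc1ccnc2cc(Cl)ccc12` gives 2710 nM, and compound 3 `Cc1c(CN2CCCC2)cc(-c2ccc(C(F)(F)F)cc2)n1Nc1ccnc2cc(Cl)ccc12` gives 2680 nM. Compound 3 sits at the lower end of the three numbers shown, but its gaps to compound 2 and to compound 1 both fall within the scatter. Among the measured compounds shown here, the only measured step on the aryl ring, a 1.0-fold lower number from compound 2 to compound 3 (0.00 log units; within the scatter), moved nothing. Compound 4 `Cc1ccc(-c2cc(CN3CCCC3)c(C)n2Nc2ccnc3cc(Cl)ccc23)cc1` differs from compound 3 by methyl in place of trifluoromethyl on an aromatic carbon. For the measured compounds named here, since the one step that bears on this position was flat, no shift beyond the scatter is expected in this assay. The expected step is a 1.0-fold higher number from compound 3 to compound 4 (0.00 log units; within the scatter). Compound 4 is therefore estimated at 2700 nM, ranging from 1400 nM to 5400 nM.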

Compound 4, half-maximal cytotoxic concentration: 4480 nM
The estimate for compound 4 lay 1.7-fold (0.22 log units) below the measured number; the measured number falls inside the stated range.
By their numbers in this assay, from the lowest: compounds 3, 2, 1 and 4 (each within the scatter of the next).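

In this assay, this aromatic carbon, para to a large group, has now carried fluoro, trifluoromethyl and methyl. Methyl adds a non-fluorinated group to the comparison, yet a 1.7-fold higher number from compound 3 to compound 4 (0.22 log units; within the scatter) and a 1.7-fold higher number from compound 2 to compound 4 (0.22 log units; within the scatter) still leave all three groups indistinguishable here. Nothing shown explains the numbers in these steps. Open, on these data alone, is whether a group of another kind at this position, such as an amine or a carboxylic acid, would give a step beyond the scatter.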